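Series notes: methoxy to hydrogen on the indole ring

A few compounds are considered here, and "the series" means these few. Any claim that something is new, unique, unknown or untested is made for them only; others in the source may bear on it.

Measured in a functional assay on MCF7 cells (Homo sapiens) for antiproliferative activity, read by CCK-8 assay, with a stated time of 48 h; on this read-out lower numbers stand for stronger inhibition and higher numbers for weaker inhibition:
Compound 1 `COc1ccc2[nH]c(C)c(C3=C(Br)C(=O)C(Br)=C(c4c(-c5ccccc5)[nH]c5ccccc45)C3=O)c2c1`: 3.38 ug/mL
Compound 2 `Cc1[nH]c2ccccc2c1C1=C(Br)C(=O)C(Br)=C(c2c(-c3ccccc3)[nH]c3ccccc23)C1=O`: 3.02 ug/mL
Compound 3 `COc1ccc2[nH]c(C)c(C3=C(Cl)C(=O)C(Cl)=C(c4c(-c5ccc(C)cc5)[nH]c5ccccc45)C3=O)c2c1`: 2.31 ug/mL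

Compound 1 and compound 2 differ by hydrogen in place of methoxy on an aromatic carbon. This gave a 1.1-fold lower number from compound 1 to compound 2 (0.05 log units; within the scatter), so the two values sit together. Compound 4 `Cc1ccc(-c2[nH]c3ccccc3c2C2=C(Cl)C(=O)C(Cl)=C(c3c(C)[nH]c4ccccc34)C2=O)cc1` is not yet measured; it differs from compound 3 by hydrogen in place of methoxy on an aromatic carbon, the same change at the same place as before. The difference between the core of compound 3 and the core of compound 1 is not broken down here; the two values themselves lie within the scatter of each other, as do those of compound 3 and compound 2.

Since the earlier occurrence of this change produced a 1.1-fold lower number from compound 1 to compound 2 (0.05 log units; within the scatter), the step from compound 3 to compound 4 is expected to be a 1.1-fold lower number from compound 3 to compound 4 (0.04 log units; within the scatter). Compound 4 is therefore estimated at 2.1 ug/mL in this assay, with a likely range from 1 ug/mL to 4.5 ug/mL.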

Compound 4, half-maximal inhibitory concentration: 2.88 ug/mL
The estimate for compound 4 lay 1.4-fold (0.14 log units) below the measured number; low and high end bracket the measured number.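

In this assay, the change from 5-methoxy-2-methyl-1H-indol-3-yl to 2-methyl-1H-indol-3-yl gave a 1.2-fold higher number from compound 3 to compound 4 (0.10 log units; within the scatter), and the two occurrences of this change agree: the same change on two cores in this assay, a 1.1-fold lower number (0.05 log units; within the scatter) from compound 1 to compound 2 and a 1.2-fold higher number (0.10 log units; within the scatter) from compound 3 to compound 4, 1.4-fold (0.14 log units) apart, within the scatter of two such steps. On these two cores, hydrogen can therefore replace methoxy with no readable shift in the number. Among these compounds, this does not show that the change is neutral on other cores, as only two cores are covered and neither step lies beyond the scatter.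

The compounds shown leave open whether an amine, a carboxylic acid or a longer alkoxy chain in place of the methoxy group would move the number beyond the scatter. They also leave open whether the agreement extends to a third core.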